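A few compounds are considered here, and "the series" means these few. Any claim that something is new, unique, unknown or untested is made for them only; others in the source may bear on it.

Compound 1 `Oc1ccc2oc(Cc3ccccc3)cc2c1CN1CCc2ccccc2C1` in a functional assay on SQ20B cells (Homo sapiens) for cytotoxicity, read by MTT assay, with a stated time of 72 h (on this read-out lower numbers stand for stronger inhibition and higher numbers for weaker inhibition), gives 16000 nM.
Compound 2 `NC(=O)C1CCN(Cc2c(O)ccc3oc(Cc4ccccc4)cc23)CC1` in this assay gives 85000 nM.
Compound 3 `Oc1ccc2oc(Cc3ccccc3)cc2c1CN1CCC(c2ccccc2)CC1` in this assay gives only a limit, > 200000 nM.

Compound 3 therefore has no exact number in this assay; it stands at the upper boundary of what was reported, while compound 1 and compound 2 each have a definite value. Compound 4 `Oc1ccc2oc(Cc3ccccc3)cc2c1CN1CCC(N2CCCC2)CC1` is a close relative of compound 3, differing in one place: pyrrolidin-1-yl in place of phenyl on a saturated ring carbon.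

Going by the values given here, only one measured step touches this position. It is an at least 2.3-fold higher number from compound 2 to compound 3 (0.37 log units; beyond the scatter), and it ended at the boundary described by the limit of > 200000 nM in this assay, at which 1 of the 3 values shown sits, so its true size is not known. Among the compounds with values here, no measured pair compares pyrrolidin-1-yl with phenyl or with carbamoyl, so the direction of the new step cannot be read from a matching example. Since the same substituent position already shifted the number by at least a modest amount once, a change there of similar magnitude is plausible again, and a return toward the range of compound 2 seems the more likely outcome. Compound 4 is estimated at 100000 nM, with a range from 30000 nM to 300000 nM. The step this estimate implies is expected to be an at least 2.0-fold lower number from compound 3 to compound 4 (0.30 log units; that floor lies within the scatter).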

Compound 4, half-maximal inhibitory concentration: 3000 nM
The estimate for compound 4 lay 33-fold (1.52 log units) above the measured number; the measured number lies below the stated range.
By their numbers in this assay, from the lowest: compound 4; then compound 1; then compound 2. At a limit, above all of these: compound 3.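

Going by these compounds alone, on the saturated ring carbon of the six-membered ring, the only earlier step, from carbamoyl to phenyl, raised the number, so it was unclear whether any group there could bring it down. In this assay, pyrrolidin-1-yl in place of carbamoyl now gives a 28-fold lower number from compound 2 to compound 4 (1.45 log units; beyond the scatter), and pyrrolidin-1-yl in place of phenyl gives an at least 66-fold lower number from compound 3 to compound 4 (1.82 log units; beyond the scatter), which shows that this position can also produce large drops and that the group placed there can change the number by a wide margin. The step from phenyl is a floor rather than a full size, and compound 3 has only a limit: the limit of > 200000 nM in this assay, at which 1 of the 4 values shown sits.

The compounds shown leave open whether the lower number goes with the nitrogen of the entering ring or with its non-aromatic ring of carbon atoms, a question that cyclopentyl at the same place, the same ring without the nitrogen, could help settle. They also leave open whether an open-chain amine such as dimethylamino, or a larger ring such as piperidin-1-yl, would behave like pyrrolidin-1-yl.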